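From compound 3 to compound 4: one change at a carbonyl

The source may report more compounds than this note shows. Statements on the series, on what has been measured and on what is new or still open speak of the compounds shown alone.

In a physicochemical assay for solubility (on this read-out lower numbers stand for lower solubility and higher numbers for higher solubility), compound 1 (`Cc1nc(C)c(C(=O)Oc2ccc(-c3cc(=O)c4c(O)c(O)c(O)cc4o3)cc2)nc1C`) gives 12.1 ug/mL, and compound 2 (`Cc1nc(C)c(C(=O)N[C@@H](C(=O)Oc2ccc(-c3cc(=O)c4c(O)c(O)c(O)cc4o3)cc2)C(C)C)nc1C`) gives 240 ug/mL. Compound 3 (`Cc1nc(C)c(C(=O)N[C@H](CC(C)C)C(=O)Oc2ccc(-c3cc(=O)c4c(O)c(O)c(O)cc4o3)cc2)nc1C`) gives 26 ug/mL, the second highest of the three numbers, with compound 1 as its nearest neighbour and compound 2 the furthest away. Within the data shown here, the unmeasured compound 4 (`Cc1nc(C)c(COC(=O)N[C@H](CC(C)C)C(=O)Oc2ccc(-c3cc(=O)c4c(O)c(O)c(O)cc4o3)cc2)nc1C`) carries (3,5,6-trimethylpyrazin-2-yl)methoxy in place of 3,5,6-trimethylpyrazin-2-yl on a carbonyl carbon, the one whose other neighbour is an amide-type nitrogen: (3,5,6-trimethylpyrazin-2-yl)methoxy in place of 3,5,6-trimethylpyrazin-2-yl on a carbonyl carbon.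

Among the measured compounds shown here, the only measured step between compounds that differ in one place is a 9.2-fold lower number from compound 2 to compound 3 (0.97 log units; beyond the scatter). That modest step concerns isobutyl in place of isopropyl on a saturated chain carbon, not the carbonyl carbon altered here, so it gives no direct guide to direction. It does show that a single change in this small set moved the number well beyond the scatter, which argues for a wide range. For the measured compounds named here, with no measured precedent at this place, no step beyond the scatter is expected in this assay. The estimate amounts to a 1.3-fold lower number from compound 3 to compound 4 (0.11 log units; within the scatter), an expected shift that stays within the scatter. For compound 4 the estimated value is 20 ug/mL, with an expected range from 6 ug/mL to 70 ug/mL.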

Compound 4, solubility: 221 ug/mL
Compound 4: middle estimate off by 11-fold (1.04 log units), on the low side, and the stated range ends below it.
By their numbers in this assay, from the lowest: compound 1; then compound 3; then compounds 4 and 2 (each within the scatter of the next).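

In this assay, the carbonyl carbon whose other neighbour is an amide-type nitrogen proves to be a place where a single change moves the number: (3,5,6-trimethylpyrazin-2-yl)methoxy in place of 3,5,6-trimethylpyrazin-2-yl gives an 8.5-fold higher number from compound 3 to compound 4 (0.93 log units; beyond the scatter). Among these compounds, until then, the only step between compounds differing in one place lay on a saturated chain carbon, a 9.2-fold lower number from compound 2 to compound 3 (0.97 log units; beyond the scatter), so this is a second place of change and a step in the opposite direction, with the number rising rather than falling. No measurement offered here speaks to why the number rose.

The compounds shown leave open whether the rise goes with the oxygen or with the extra carbon of the entering group, a question that (3,5,6-trimethylpyrazin-2-yl)methyl or (3,5,6-trimethylpyrazin-2-yl)amino on the same carbonyl carbon would help to separate. Also open, from the compounds shown here alone, is whether the same change would move the number in the same direction with isopropyl in place of isobutyl on the saturated chain carbon, as this step is read with isobutyl alone.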